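The source may report more compounds than this note shows. Statements on the series, on what has been measured and on what is new or still open speak of the compounds shown alone.

Measured in a functional assay on EA.hy 926 cells (Homo sapiens) for cytotoxicity, read by MTT assay, with stated times of 24 h and 12 h, tested at 12.5 uM; a lower number here means a weaker effect, a higher number a stronger effect of the compound at the concentration tested:
compound 1 `CCOC(=O)/C=C/c1cc(OC)c(OC(=O)c2nc(C)c(C)nc2C)c(OC)c1` gives 96.6%
compound 2 `CCOC(=O)/C=C/c1cc(OC)c(O)c(OC)c1` gives 4.9%
compound 3 `COc1cc(/C=C/C(=O)O)cc(OC)c1OC(=O)c1nc(C)c(C)nc1C` gives 5.7%

Compound 1 stands highest of the three; compound 3 and compound 2 both lie far below it, each beyond the scatter. Among the measured compounds shown here, the one measured step, a number 90.9 percentage points lower from compound 1 to compound 3 (beyond the scatter), is large, but it alters the ethyl ester, which compound 4 keeps. Compound 4 `CCOC(=O)/C=C/c1ccc(OC(=O)c2nc(C)c(C)nc2C)c(OC)c1` differs from compound 1 only by hydrogen in place of methoxy on an aromatic carbon. For the measured compounds named here, no measured step touches that position, so the direction of the step in this assay cannot be read from the series; the pyrazine ester and the ethyl ester, both retained, are the only features tied to the high reading of compound 1. Compound 4 is therefore expected to stay toward the upper part of the range, with wide uncertainty: 70% (30% to 98%), an expected step of a number 26.6 percentage points lower from compound 1 to compound 4 (beyond the scatter).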

Compound 4, a percentage reported as activity, at one concentration (the size of the read-out at that concentration, not a potency): 52.4%
The estimate for compound 4 lay 17.6 percentage points above the measured number; the measured number falls inside the stated range.
By their numbers in this assay, from the lowest: compounds 2 and 3 (each within the scatter of the next); then compound 4; then compound 1.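

In this assay, among the compounds shown here, hydrogen in place of methoxy on this aromatic carbon gives a number 44.2 percentage points lower from compound 1 to compound 4 (beyond the scatter) and so shows what the earlier steps could not: this position bears on the reading. The ethyl ester and the large group, both retained in compound 4, do not alone keep the reading of compound 1.

Open, on these data alone, is whether ethoxy, hydroxyl or an amine on this carbon would hold the reading. Also open, as far as these compounds go, is whether the same change would matter with the carboxylic acid of compound 3.

No measurement at hand explains the step.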